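The source may hold more compounds than are shown below. What is called first, only, known or untested is meant among the compounds shown, and "the series" means these compounds.

Going by the values given here, in a functional assay on ECa-109 cells for antiproliferative activity against ECa-109 cell line (Homo sapiens), read by MTT assay, with a stated time of 72 h (on this read-out higher numbers stand for weaker inhibition and lower numbers for stronger inhibition), compound 2 `C/C(=N\NC(=O)c1cccc(S(=O)(=O)N2CCOCC2)c1)c1ccccc1O` gives 5450 nM, the only actual number so far. Compound 1 `C/C(=N\NC(=O)c1cccc(S(=O)(=O)N2CCOCC2)c1)c1cccc(N)c1` reads > 100000 nM, which is a limit of the assay. Compound 3 `C/C(=N\NC(=O)c1cccc(S(=O)(=O)N2CCOCC2)c1)c1cccc(O)c1` reads > 100000 nM, also a limit.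

The step to compound 4 `C/C(=N\NC(=O)c1cccc(S(=O)(=O)N2CCOCC2)c1)c1cc(Br)ccc1O` is bromo in place of hydrogen on an aromatic carbon, para to a hydroxy group, turning 2-hydroxyphenyl into 5-bromo-2-hydroxyphenyl. The measured steps nearest to it are an at least 18-fold lower number from compound 1 to compound 2 (1.26 log units; beyond the scatter) and an at least 18-fold higher number from compound 2 to compound 3 (1.26 log units; beyond the scatter), both large and beyond the scatter. Both concern the aryl group that changes here, but neither adds a bromo, so neither gives the size of this step directly. Compound 4 keeps the 2-hydroxyphenyl arrangement that compound 2 carries at 5450 nM, so a loss on the scale of those steps is not expected. The expected change is small, a 1.8-fold lower number from compound 2 to compound 4 (0.26 log units; within the scatter), leaning towards a lower number and possibly not beyond the scatter. For compound 4 the estimated value is 3000 nM, with an expected range of 800 nM to 12000 nM.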

Compound 4, half-maximal inhibitory concentration: 5280 nM
The estimate for compound 4 lay 1.8-fold (0.25 log units) below the measured number; measured number inside the range.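

In this assay, bromo on the aromatic carbon para to a hydroxy group gives a 1.0-fold lower number from compound 2 to compound 4 (0.01 log units; within the scatter), so this position of the 2-hydroxyphenyl group accepts a bromo with no step beyond the scatter. With the bromo present, the 5-bromo-2-hydroxyphenyl group still stands apart from the 3-hydroxyphenyl and 3-aminophenyl groups, with an at least 18-fold lower number from compound 3 to compound 4 (1.27 log units; beyond the scatter) and an at least 18-fold lower number from compound 1 to compound 4 (1.27 log units; beyond the scatter). Both of these steps start from a limit of the assay and not from a number: the limit of > 100000 nM in this assay, at which 2 of the 4 values shown sit.

The compounds shown leave open whether a chloro, a methoxy or a carboxylic acid on this same carbon would read like the bromo. They also leave open whether a bromo on any other carbon of this ring would do the same.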